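A few compounds are considered here, and "the series" means these few. Any claim that something is new, unique, unknown or untested is made for them only; others in the source may bear on it.

Measured in a physicochemical assay for solubility, at pH 6.8; a lower number here means a less soluble compound, a higher number a more soluble compound:
- compound 1 `Nc1ncnc2c1c(-c1ccc3cc[nH]c3c1)cn2-c1ccc(OCCNCCO)cc1`: 46000 nM
- compound 2 `NCc1ccc(-n2cc(-c3ccc4cc[nH]c4c3)c(C(F)(F)F)n2)cc1`: 62000 nM

Compound 2, at 62000 nM, stands within the usual scatter of compound 1, at 46000 nM, so the two cannot be told apart. Compound 3 `FC(F)(F)c1nn(-c2ccc(Cc3nc[nH]n3)cc2)cc1-c1ccc2cc[nH]c2c1` differs from compound 2 by one change: 1H-1,2,4-triazol-3-yl in place of amino on a saturated chain carbon bound to an aromatic carbon, with 1H-1,2,4-triazol-3-yl in place of amino on a saturated chain carbon bound to an aromatic carbon. For the measured compounds named here, no measured pair shows this change, so the expectation is loose: a moderate fall in this assay. The expected step is a 3.4-fold lower number from compound 2 to compound 3 (0.54 log units; beyond the scatter). Compound 3 is estimated at 18000 nM, within a range of 4000 nM to 70000 nM.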

Compound 3, solubility: 11000 nM
Compound 3: middle estimate off by 1.6-fold (0.21 log units), on the high side; the measured number falls inside the stated range.
By their numbers in this assay, from the lowest: compound 3; then compounds 1 and 2 (each within the scatter of the next).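

On the saturated chain carbon bound to an aromatic carbon, this assay does respond to what that carbon carries: replacing amino with 1H-1,2,4-triazol-3-yl gives a 5.6-fold lower number from compound 2 to compound 3 (0.75 log units; beyond the scatter). For the compounds shown here, this is the first one-place comparison available, since compound 1 and compound 2 differ in more than one place. No measurement here explains the fall. With a single step, the compounds shown leave open whether the loss of amino or the arrival of the triazole ring matters more. They also leave open how a carboxylic acid, or a longer chain ending in amino, would compare at this position.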